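The source may hold more compounds than are shown below. What is called first, only, known or untested is meant among the compounds shown, and "the series" means these compounds.

Compound 1 `COc1cc(C(=O)c2sc(-c3cccs3)cc2N)cc(OC)c1OC` is the starting point. For the measured compounds named here, in a functional assay on CCRF-CEM cells (Homo sapiens) for antiproliferative activity (a higher number here means a weaker inhibitor, a lower number a stronger inhibitor), compound 1 gives 9.4 nM, the lowest of the three numbers measured so far. Compound 2 `CCOc1ccc(-c2cc(N)c(C(=O)c3cc(OC)c(OC)c(OC)c3)s2)cc1` gives 270 nM, and compound 3 `COc1cc(C(=O)c2sc(-c3ccc(I)cc3)cc2N)cc(OC)c1OC` gives 150 nM. Compound 4 `COc1cc(C(=O)c2sc(-c3ccncc3)cc2N)cc(OC)c1OC` is the new compound, and it differs from compound 1 in one place: pyridin-4-yl in place of thiophen-2-yl on an aromatic carbon Two measured steps bear on this, since both of them also removed the thiophen-2-yl group from the shared core: a 29-fold higher number from compound 1 to compound 2 (1.46 log units; beyond the scatter) and a 16-fold higher number from compound 1 to compound 3 (1.20 log units; beyond the scatter). Between those two products the difference is small, a 1.8-fold lower number from compound 2 to compound 3 (0.26 log units; within the scatter), so the loss appears tied to what was removed rather than to what replaced it. A large step towards a weaker inhibitor is therefore expected for compound 4 in this assay. The expected step is a 13-fold higher number from compound 1 to compound 4 (1.11 log units; beyond the scatter). Compound 4 is estimated at 120 nM, with a range from 30 nM to 500 nM.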

Compound 4, half-maximal inhibitory concentration: 110 nM
For compound 4 the middle estimate is 1.1-fold (0.04 log units) above the measured one; the range from low to high includes it.
By their numbers in this assay, from the lowest: compound 1; then compounds 4, 3 and 2 (each within the scatter of the next, the first and the last beyond it).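

Pyridin-4-yl carries no further group on its ring, yet in this assay it still gives a 12-fold higher number from compound 1 to compound 4 (1.07 log units; beyond the scatter), so the loss at this position does not depend on the iodo or ethoxy group of the earlier replacements. Compound 4 also stands level with the iodo compound, at a 1.4-fold lower number from compound 3 to compound 4 (0.13 log units; within the scatter), but the ethoxy compound differs from it, at a 2.5-fold lower number from compound 2 to compound 4 (0.39 log units; beyond the scatter), so the group entering here does have some influence on the number. Across these four compounds, the only one with the low number carries the five-membered thiophen-2-yl, while all three with six-membered aromatic rings have much higher numbers.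

No measurement shown offers a reason for this loss. Going by these compounds, whether a plain phenyl, a furan-2-yl or a thiophen-3-yl group would keep the number of compound 1 remains open.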